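The source may hold more compounds than are shown below. What is called first, only, known or untested is meant among the compounds shown, and "the series" means these compounds.

The measured compounds, in a functional assay on BMDM cells (Mus musculus, strain C57BL/6) for inhibition, with a stated time of 2 days; a lower number here means a stronger inhibitor, a higher number a weaker inhibitor:

Compound 1 `Cc1csc(NC(=O)Cn2cc(-c3cccs3)nn2)n1` gives 40 nM in this assay.
Compound 2 `Cc1cc(NC(=O)Cn2cc(-c3cccc(Cl)c3)nn2)no1` gives only a limit of the assay in this assay, > 30000 nM.
Compound 3 `O=C(Cn1cc(-c2cccc(Cl)c2)nn1)Nc1nccs1` likewise gives only a limit of the assay in this assay, > 30000 nM.

Compound 2 therefore does not stand at a number at all: it sits at the limit of > 30000 nM in this assay, at which 2 of the 3 values shown sit. For the measured compounds named here, the only step between measured compounds that differ in one place is a step that the two limits leave unreadable from compound 2 to compound 3, and since both ends are limits its size cannot be read. Going by the values given here, compound 1 shares no single-place change with compound 2 or compound 3, so its value gives no step to either of them.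

Compound 4 `Cc1cc(NC(=O)Cn2cc(-c3ccc(Cl)cc3)nn2)no1` differs from compound 2 in one place: 4-chlorophenyl in place of 3-chlorophenyl on an aromatic carbon. The two compounds have the same atoms, joined differently. Among the compounds with values here, none of the measured steps bears on this change; the one step recorded concerns the amide-type nitrogen, not the aromatic carbon of the five-membered ring, and it is unreadable besides. Within the data shown here, compound 1 is the only compound with a number, and it differs from compound 4 in more than one place.

With compound 2 at a limit because of the limit of > 30000 nM in this assay, at which 2 of the 3 values shown sit, compound 4 is expected to remain near that limit as well, with an estimated value of 30000 nM in this assay, between 3000 nM and 100000 nM. The step this estimate implies, a number no higher from compound 2 to compound 4 (the limit leaves the size open), is expected to be one that the limit on compound 2 leaves unreadable.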

Compound 4, half-maximal inhibitory concentration: 1910 nM
For compound 4 the middle estimate is 16-fold (1.20 log units) above the measured one; measured number outside the range, below it.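

In this assay, putting 4-chlorophenyl in place of 3-chlorophenyl on the aromatic carbon of the five-membered aromatic ring with 3 nitrogen gives an at least 15-fold lower number from compound 2 to compound 4 (1.19 log units; beyond the scatter). This position therefore responds to where the chlorine stands on the phenyl ring, even though the two compounds have the same atoms, and it gives the first readable step among these compounds, the earlier one having been left unreadable by two limits. The true size of this step stays open-ended, since compound 2 stands at a limit and not at a number: the limit of > 30000 nM in this assay, at which 2 of the 4 values shown sit.

It remains open whether the same exchange has a comparable effect on the 1,3-thiazol-2-yl amide of compound 3, where the 3-chlorophenyl compound also stands at a limit, and what lies behind the step is not shown by these compounds. Also open, from the compounds shown here alone, is how a phenyl ring carrying a methoxy group or an amine in place of the chlorine would read in this assay on this same carbon.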